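The compounds below may be only part of what the source reports. "The series", "measured", "known", "first", "only" and "open" are said of these compounds alone.

Measured in an ADME assay on RAW264.7 cells (Mus musculus) for cytotoxicity, read by MTT assay, with a stated time of 24 h, in the absence of a further agent (a lower number here means a stronger inhibitor, a higher number a weaker inhibitor), each entry being a limit of the assay:

- compound 1 `COc1cc(OC)c2c(c1)C(C(O)c1ccc(O)cc1)OC2=O`: > 40000 nM
- compound 2 `CCC(C)Oc1ccc(C(O)C2OC(=O)c3c(OC)cc(OC)cc32)cc1`: > 40000 nM
- compound 3 `COCCCOc1ccc(C(O)C2OC(=O)c3c(OC)cc(OC)cc32)cc1`: > 40000 nM

Compound 3 stands at > 40000 nM, which is a limit and not a number. The other two compounds offer no number to set against it, and the whole series shows (the limit of > 40000 nM in this assay, at which 3 of the 3 values shown sit).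

Compound 4 `C=CCCOc1ccc(C(O)C2OC(=O)c3c(OC)cc(OC)cc32)cc1` differs from compound 3 at the end of its chain: vinyl in place of methoxymethyl on a saturated chain carbon, two bonds along the chain from an oxygen on an aromatic ring. Put simply, 3-methoxypropyl gives way to but-3-en-1-yl on the same oxygen on an aromatic ring.

The measured steps that bear on this are changes at that same oxygen: a step that the two limits leave unreadable from compound 1 to compound 2, a step that the two limits leave unreadable from compound 1 to compound 3 and a step that the two limits leave unreadable from compound 2 to compound 3. Both ends of each step are limits, so none of them has a size that can be read. They do show that hydrogen, sec-butyl and 3-methoxypropyl on that oxygen all end at the same limit.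

No clear step, up or down, is therefore expected in this assay, and the estimated change is a step that the limit leaves unreadable from compound 3 to compound 4. The most likely result is another limit. As a value, compound 4 is estimated at 50000 nM, with an expected range from 25000 nM to 100000 nM.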

Compound 4, half-maximal inhibitory concentration: > 40000 nM
Compound 4 gave a limit, no number; the forecaster's own chance of this, stated with the estimate: 85%; the middle value is on the limit's open side.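

In this assay compound 4 gives > 40000 nM, which is a limit and not a number. Its steps from compound 1, compound 2 and compound 3 therefore cannot be read, and all four compounds share one result: the limit of > 40000 nM in this assay, at which 4 of the 4 values shown sit.

The compounds shown leave open whether any group on that oxygen changes the result in this assay at all, as none of them gives a number.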